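An amide substituent swap on compound 2

The source may report more compounds than this note shows. Statements on the series, on what has been measured and on what is new or still open speak of the compounds shown alone.

Measured in a physicochemical assay for lipophilicity, measured as octanol-water partition, at pH 7.4; a higher number here means a more lipophilic compound, a lower number a more polar compound:
- compound 1 `Cc1ccc2[nH]c(C(=O)N[C@H]3CN(S(=O)(=O)c4ccccc4)C[C@@H]3C(=O)N[C@H]3CCCNC3)cc2c1`: 1.3
- compound 2 `O=C(N[C@H]1CN(S(=O)(=O)c2ccccc2)C[C@@H]1C(=O)NC[C@@H]1CCCN1)c1cc(-c2ccccc2Cl)on1`: 1.5

Compound 2 stands at 1.5, within the scatter of compound 1 at 1.3, so the two cannot be ordered. Compound 3 `CC(=O)N1CCC[C@H](NC(=O)[C@H]2CN(S(=O)(=O)c3ccccc3)C[C@@H]2NC(=O)c2cc(-c3ccccc3Cl)on2)C1` carries 1-acetylpiperidin-3-yl in place of the (pyrrolidin-2-yl)methyl of compound 2 on an amide-type nitrogen (1-acetylpiperidin-3-yl in place of (pyrrolidin-2-yl)methyl on an amide-type nitrogen). Within the data shown here, no measured pair shows this change, so the expectation rests on the structural change alone: an upward step in this assay, beyond the scatter. The expected step is a number 1.30 log units higher from compound 2 to compound 3 (beyond the scatter). For compound 3 the estimated value is 2.8, with an expected range from 2.3 to 3.3.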

Compound 3, distribution coefficient: 3.5
Compound 3: the middle estimate sits 0.70 log units below what was measured; the measured number lies above the stated range.
By their numbers in this assay, from the lowest: compounds 1 and 2 (each within the scatter of the next); then compound 3.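

Replacing (pyrrolidin-2-yl)methyl with 1-acetylpiperidin-3-yl on the amide-type nitrogen gives the first step read at this position: in this assay the value rises by a number 2.00 log units higher from compound 2 to compound 3 (beyond the scatter), a large change from one substitution. The entering group has 9 heavy atoms and 0 hydrogen-bond donors, the leaving group 6 and 1, so several features change together. Nothing measured here says which of them accounts for the step. Open, from the compounds shown here alone, is whether the acetyl matters or the six-membered ring alone carries the step, which a 1-methylpiperidin-3-yl group or the free piperidin-3-yl amine could separate.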